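The source may report more compounds than this note shows. Statements on the series, on what has been measured and on what is new or still open speak of the compounds shown alone.

Compound 1 `C#CCN(CCCOc1ccc2ccc(=O)oc2c1)Cc1ccc(C)cc1` has been measured in an ADME assay on isolated protein for inhibition of Amine oxidase [flavin-containing] A (Homo sapiens), read by fluorescence and Amplex Red, with stated times of 15 min and 20 min (a lower number here means a stronger inhibitor, a higher number a weaker inhibitor), where compound 1 gives 116000 nM. Among the compounds with values here, the only other measured compound, compound 2 `C#CCN(CCCCOc1ccc2ccc(=O)oc2c1)Cc1ccccc1`, differs from it in more than one place, so no single step connects the two. In this assay compound 2 gives 89400 nM, a number that lies within the scatter of repeated measurements relative to the value of compound 1, and on these two numbers neither can be called the stronger or the weaker inhibitor. Compound 3 `C#CCN(CCCOc1ccc2ccc(=O)oc2c1)Cc1cccc(OC)c1` has not yet been measured. It differs from compound 1 by a single change: 3-methoxyphenyl in place of 4-methylphenyl on a saturated chain carbon bound to an amine nitrogen. Within the data shown here, no measured pair shows what this change does in this assay, so the expected step is uncertain and is taken as small, a 1.2-fold lower number from compound 1 to compound 3 (0.09 log units; within the scatter), with no direction expected beyond the scatter. Compound 3 is therefore estimated at 95000 nM in this assay, within a range from 30000 nM to 300000 nM.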

Compound 3, half-maximal inhibitory concentration: 22700 nM
Estimate against measurement, compound 3: 4.2-fold (0.62 log units) above, outside the stated range (below it).
By their numbers in this assay, from the lowest: compound 3; then compounds 2 and 1 (each within the scatter of the next).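

Within the data shown here, replacing 4-methylphenyl with 3-methoxyphenyl on a saturated chain carbon bound to an amine nitrogen gives a 5.1-fold lower number from compound 1 to compound 3 (0.71 log units; beyond the scatter) in this assay, the first single-place step in this set. It shows that the number in this assay responds to the group at this position, and that this change moves it towards stronger inhibition by more than the scatter. Nothing given here accounts for the size or direction of this step.

The step alters the substituent and its ring position together, so the compounds shown do not separate the two; 3-methylphenyl and 4-methoxyphenyl at the same place would do so. Also open, from the compounds shown here alone, is whether 3-methoxyphenyl gives a similar step on a longer chain, or whether other groups, such as 3-chlorophenyl, do the same here.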